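The source may hold more compounds than are shown below. What is called first, only, known or untested is meant among the compounds shown, and "the series" means these compounds.

Compound 1 `CCCc1cc(N)c2cc(NC(=O)/C=C/c3ccc(N)cc3)ccc2n1`: 190 nM
Compound 2 `CCCc1cc(N)c2cc(NC(=O)/C=C/c3ccc(CC)cc3)ccc2n1`: 1.4 nM
Compound 3 `CCCc1cc(N)c2cc(NC(=O)/C=C/c3ccc(F)cc3)ccc2n1`: 130 nM

These three share one core and differ only in a single group on the outer aromatic ring. In an assay on isolated protein for displacement of a labelled ligand from melanin-concentrating hormone receptor 1 (Homo sapiens) (on this read-out higher numbers stand for weaker inhibition and lower numbers for stronger inhibition), compound 3 gives 130 nM, the second highest of the three numbers; compound 1 lies nearest, with a 1.5-fold lower number from compound 1 to compound 3 (0.16 log units; within the scatter), while compound 2 lies furthest, with a 93-fold higher number from compound 2 to compound 3 (1.97 log units; beyond the scatter). Compound 4 `CCCCc1ccc(/C=C/C(=O)Nc2ccc3nc(CCC)cc(N)c3c2)cc1` carries butyl in place of fluoro on an aromatic carbon. The step that bears most on it is a 93-fold higher number from compound 2 to compound 3 (1.97 log units; beyond the scatter), where an ethyl chain gave a far lower number than fluoro, and a 140-fold lower number from compound 1 to compound 2 (2.13 log units; beyond the scatter) points the same way for a chain there. Butyl is a longer chain than ethyl, and no measured compound shows how length matters, so a large fall is expected but with wide bounds. Compound 4 is estimated at 3 nM, range 0.8 nM to 15 nM, which would mean a 43-fold lower number from compound 3 to compound 4 (1.64 log units; beyond the scatter).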

Compound 4, half-maximal inhibitory concentration: 45 nM
Compound 4: middle estimate off by 15-fold (1.18 log units), on the low side, and the stated range ends below it.
By their numbers in this assay, from the lowest: compound 2; then compound 4; then compounds 3 and 1 (each within the scatter of the next).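

Making the chain longer at this position does not keep lowering the number: butyl gives up much of what ethyl gained, with a 32-fold higher number from compound 2 to compound 4 (1.51 log units; beyond the scatter). Butyl still improves on the two non-chain groups, with a 2.9-fold lower number from compound 3 to compound 4 (0.46 log units; beyond the scatter) and a 4.2-fold lower number from compound 1 to compound 4 (0.63 log units; beyond the scatter), so a chain helps here, but length matters. Nothing measured here says why the longer chain loses ground.

Among the compounds shown here, with only two chain lengths, the best length cannot be placed. As far as these compounds go, it remains open how propyl, methyl or a branched chain such as isopropyl would compare with ethyl.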